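The source may report more compounds than this note shows. Statements on the series, on what has been measured and on what is new or still open speak of the compounds shown alone.

Measured in a functional assay on A549 cells (Homo sapiens) for cytotoxicity, read by MTT assay, with a stated time of 72 h; on this read-out higher numbers stand for weaker inhibition and lower numbers for stronger inhibition:
- compound 1 `CN(C)CCCCCn1c2c(c3ccccc31)C(=O)c1c[n+]([O-])c3ccccc3c1C2=O`: 210 nM
- compound 2 `O=C1c2c[n+]([O-])c3ccccc3c2C(=O)c2c1c1ccccc1n2CCN1CCCC1`: 410 nM
- compound 3 `O=C1c2c[n+]([O-])c3ccccc3c2C(=O)c2c1c1ccccc1n2CCCCN1CCCCC1`: 150 nM

Compound 3 shares the low end of this set with compound 1: the data show a 1.4-fold lower number from compound 1 to compound 3 (0.15 log units; within the scatter), and also a 2.7-fold lower number from compound 2 to compound 3 (0.44 log units; beyond the scatter). Compound 4 `CN1CCN(CCCn2c3c(c4ccccc42)C(=O)c2c[n+]([O-])c4ccccc4c2C3=O)CC1` differs from compound 3 as follows: 4-methylpiperazin-1-yl in place of (piperidin-1-yl)methyl on a saturated chain carbon, three bonds along the chain from an aromatic nitrogen. Read one bond further out, 3-(4-methylpiperazin-1-yl)propyl takes the place of 4-(piperidin-1-yl)butyl. Among the measured compounds shown here, those two measured steps bear on this change, since each alters the chain and its end group together, yet no measured compound carries 4-methylpiperazin-1-yl. A small rise in the number is therefore expected, with no step beyond the scatter. The expected step is a 1.7-fold higher number from compound 3 to compound 4 (0.22 log units; within the scatter). For compound 4 the estimate is 250 nM, with an expected range of 100 nM to 600 nM.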

Compound 4, half-maximal inhibitory concentration: 140 nM
For compound 4 the middle estimate is 1.8-fold (0.25 log units) above the measured one; measured number inside the range.
By their numbers in this assay, from the lowest: compounds 4, 3, 1 and 2 (each within the scatter of the next, the first and the last beyond it).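

In this assay, 3-(4-methylpiperazin-1-yl)propyl proves interchangeable with 4-(piperidin-1-yl)butyl, as a 1.1-fold lower number from compound 3 to compound 4 (0.03 log units; within the scatter) shows, and a 1.5-fold lower number from compound 1 to compound 4 (0.18 log units; within the scatter) places it level with the dimethylamino chain too, so the second ring nitrogen and the shorter chain together leave the number in place. Only the pyrrolidin-1-yl compound stands apart, with a 2.9-fold lower number from compound 2 to compound 4 (0.47 log units; beyond the scatter) marking the gap. No evidence here explains these results. The compounds shown leave open whether morpholin-4-yl on the same propyl chain would hold this level. They also leave open whether 4-methylpiperazin-1-yl would do so on an ethyl or butyl chain.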